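This account rests on a few compounds, and the source may have more. Where it says the series, first, only, none or still open, it means among the compounds named here.

Working notes on the series. Compound 1 is `Cc1c(O)ccc2c1[C@H](Cn1cc(-c3ccc(F)cc3)nn1)[C@@]13CC(=O)[C@@](C)(CC[C@@H]21)C3`. In a functional assay on HL-60 cells (Homo sapiens) for cytotoxicity, read by MTT assay, with a stated time of 4 days (a higher number here means a weaker inhibitor, a lower number a stronger inhibitor), compound 1 gives only a limit, > 20000 nM. Compound 2 is `Cc1c(O)ccc2c1[C@H](Cn1cc(-c3ccc(Cl)cc3)nn1)[C@@]13CC(=O)[C@@](C)(CC[C@@H]21)C3`. In this assay compound 2 gives only a limit, > 20000 nM. Compound 3 is `Cc1c(O)ccc2c1[C@H](Cn1cc(-c3ccccn3)nn1)[C@@]13CC(=O)[C@@](C)(CC[C@@H]21)C3`. In this assay compound 3 likewise gives only a limit, > 20000 nM. Compound 3 therefore stands where the whole set stands, at the limit of > 20000 nM in this assay, at which 3 of the 3 values shown sit.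

The measured steps bearing on exchanges of the group on the five-membered aromatic ring, a step that the two limits leave unreadable from compound 1 to compound 2, a step that the two limits leave unreadable from compound 1 to compound 3 and a step that the two limits leave unreadable from compound 2 to compound 3, all run between limits and have no readable size; no exchange of that group has yet produced a number.

Compound 4 is `Cc1c(O)ccc2c1[C@H](Cn1cc(-c3ccc(C(F)(F)F)cc3)nn1)[C@@]13CC(=O)[C@@](C)(CC[C@@H]21)C3`. The change from compound 3 is 4-(trifluoromethyl)phenyl in place of pyridin-2-yl on an aromatic carbon. Since the three comparable exchanges left every value at the limit, no step beyond the scatter is expected in this assay; the expected step is a step that the limit leaves unreadable from compound 3 to compound 4. For compound 4 the estimate is 25000 nM, with a range from 8000 nM to 60000 nM, most probably reported again as a limit.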

Compound 4, half-maximal inhibitory concentration: > 20000 nM
Compound 4: no number, only a limit; the forecaster's own chance of this, stated with the estimate: 80%; the middle value does not contradict the limit.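

In this assay compound 4 gives only a limit, > 20000 nM, so its steps from compound 1, compound 2 and compound 3 cannot be read. The compounds shown leave open whether any exchange of this group on the five-membered aromatic ring yields a number, since all stand at one limit: the limit of > 20000 nM in this assay, at which 4 of the 4 values shown sit.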